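From 3,4-dichlorophenyl to 4-chlorophenyl on a shared core

A few compounds are considered here, and "the series" means these few. Any claim that something is new, unique, unknown or untested is made for them only; others in the source may bear on it.

Compound 1 `O=C(/C=C/C(=O)N1C/C(=C\c2ccccc2)C(=O)/C(=C/c2ccccc2)C1)Nc1ccc(Cl)c(Cl)c1`: 350 nM
Compound 2 `O=C(/C=C/C(=O)N1C/C(=C\c2ccc([N+](=O)[O-])cc2)C(=O)/C(=C/c2ccc([N+](=O)[O-])cc2)C1)Nc1ccc(Cl)c(Cl)c1`: 380 nM

In a functional assay on CCRF-CEM cells (Homo sapiens) for cytotoxicity (a higher number here means a weaker inhibitor, a lower number a stronger inhibitor), compound 2 gives 380 nM, which lies within the usual scatter of compound 1 at 350 nM. These two compounds are the only measured points so far. Compound 3 `O=C(/C=C/C(=O)N1C/C(=C\c2ccc([N+](=O)[O-])cc2)C(=O)/C(=C/c2ccc([N+](=O)[O-])cc2)C1)Nc1ccc(Cl)cc1` departs from compound 2 at a single place: hydrogen in place of chloro on an aromatic carbon. This puts hydrogen in place of chloro on an aromatic carbon, ortho to a chloro group, and turns 3,4-dichlorophenyl into 4-chlorophenyl. Within the data shown here, no measured pair shows this change on its own, so there is no direct precedent for its size. No step beyond the scatter is expected in this assay. The estimated change is a 1.3-fold higher number from compound 2 to compound 3 (0.10 log units; within the scatter). Compound 3 is estimated at 480 nM, with an expected range of 180 nM to 1300 nM.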

Compound 3, half-maximal inhibitory concentration: 810 nM
Compound 3: middle estimate off by 1.7-fold (0.23 log units), on the low side, within the range that was stated.
By their numbers in this assay, from the lowest: compounds 1 and 2 (each within the scatter of the next); then compound 3.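

Taking one chloro group off the ring, so that 3,4-dichlorophenyl becomes 4-chlorophenyl, gives a 2.1-fold higher number from compound 2 to compound 3 (0.33 log units; beyond the scatter) in this assay. Among these compounds, this is the first single-place step, and it shows that the chloro group on this aromatic carbon, ortho to a chloro group, counts for something, although the step is modest and rests on this one pair. Nothing available explains why the number rises at this position.

As far as these compounds go, whether the same step appears on the core of compound 1, which carries no nitro groups, remains open. From the compounds shown here alone, it is also open how a methoxy or trifluoromethyl group at this place would compare with chloro and hydrogen, and what happens when the remaining chloro group of the 4-chlorophenyl ring is replaced by an amine.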